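Compound 1 to compound 4: substituent on the amide nitrogen

The source may report more compounds than this note shows. Statements on the series, on what has been measured and on what is new or still open speak of the compounds shown alone.

Compound 1 `CCC1C(=O)N(C)c2cnc(-n3ccc4cc(C(=O)NC(C)C)ccc43)nc2N1c1ccn(C)n1` carries an isopropyl group on its amide-type nitrogen. Going by the values given here, in an assay for inhibition of serine/threonine-protein kinase PLK2 (Homo sapiens), read by FRET and Z'-LYTE, with a stated time of 1 h (a higher number here means a weaker inhibitor, a lower number a stronger inhibitor), compound 1 gives 125 nM, the highest of the three numbers measured so far. Compound 2 `CCCNS(=O)(=O)c1ccc(Nc2ncc3c(n2)N(C2CCCC2)[C@H](CC)C(=O)N3C)cc1` gives 17.8 nM, and compound 3 `CC[C@@H]1C(=O)N(C)c2cnc(Nc3ccc(S(=O)(=O)NCCCO)cc3)nc2N1C1CCCC1` gives 8.16 nM; both sit below compound 1 by more than the scatter. Among the compounds with values here, the only single-point step measured is a 2.2-fold lower number from compound 2 to compound 3 (0.34 log units; beyond the scatter), a modest change on a saturated chain three bonds along from a sulfonamide nitrogen, in a region of the molecule unrelated to the change considered here. Compound 4 `CCC1C(=O)N(C)c2cnc(-n3ccc4cc(C(=O)NCC(C)C)ccc43)nc2N1c1ccn(C)n1` differs from compound 1 by isobutyl in place of isopropyl on an amide-type nitrogen whose other neighbour is a carbonyl carbon. Within the data shown here, no measured step speaks to a change of this kind, so the expectation rests on compound 1 alone. A step of about a 1.1-fold lower number from compound 1 to compound 4 (0.04 log units; within the scatter) is expected, which is no movement beyond the scatter. Compound 4 is therefore estimated at 115 nM, with a range of 50 nM to 260 nM.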

Compound 4, half-maximal inhibitory concentration: 159 nM
Beside the measured number, compound 4's estimate is 1.4-fold (0.14 log units) below it; low and high end bracket the measured number.
By their numbers in this assay, from the lowest: compound 3; then compound 2; then compounds 1 and 4 (each within the scatter of the next).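

In this assay, going by these compounds alone, the step of a 1.3-fold higher number from compound 1 to compound 4 (0.10 log units; within the scatter) is the first reading at this position, and it leaves isobutyl and isopropyl on the amide-type nitrogen within the scatter of each other. For this pair on the core of compound 1, the change from isopropylcarbamoyl to isobutylcarbamoyl therefore gives no separable difference in the number, though one pair defines no trend for the position. No measured evidence bears on this result.

Still open, on these data alone, is whether a group of a different kind on this nitrogen, such as a longer chain, a cyclohexyl ring, or a chain ending in an amine or a carboxylic acid, would move the number beyond the scatter. Also open, as far as these compounds go, is whether the same isobutyl for isopropyl change would read alike on a different core.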